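The source may report more compounds than this note shows. Statements on the series, on what has been measured and on what is new or still open speak of the compounds shown alone.

In a functional assay on HL-60 cells (Homo sapiens) for antiproliferative activity, with a stated time of 72 h (on this read-out lower numbers stand for stronger inhibition of growth and higher numbers for weaker inhibition of growth), compound 1 (`C=C(CCCC)C(=O)c1ccc(OC(C)C(=O)OC)c(C)c1C`) gives a measured 5200 nM. Compound 2 (`C=C(CC)C(=O)c1ccc(OCC(=O)O)cc1C`) is reported only as a limit, > 60000 nM. As far as these compounds go, compound 3 (`C=C(CC)C(=O)c1ccc(OCC(=O)O)cc1Br`) is likewise reported only as a limit, > 60000 nM, so its true position is unknown. That leaves the acid pair with the limit of > 60000 nM in this assay, at which 2 of the 3 values shown sit.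

Compound 4 (`C=C(CC)C(=O)c1ccc(OCC(=O)O)cc1Cl`) has chloro in place of bromo on an aromatic carbon, ortho to a group of 6 heavy atoms and meta to a carboxymethoxy group: chloro in place of bromo on an aromatic carbon.

Among the compounds with values here, the one measured step that bears on this change is a step that the two limits leave unreadable from compound 2 to compound 3, and its size cannot be read. It offers no sign of a change at this carbon, and no size can be carried over from it. No step beyond the scatter is therefore expected in this assay, and another limit report is the likeliest outcome. The expected step is a step that the limit leaves unreadable from compound 3 to compound 4. For compound 4 the estimate is 65000 nM, with an expected range from 30000 nM to 130000 nM.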

Compound 4, concentration for 50% growth inhibition: > 60000 nM
Compound 4: only a limit was reported (the forecaster's own chance of this, stated with the estimate: 85%); the middle value does not contradict the limit.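

Compound 2, compound 3 and compound 4 are all reported only as limits, so no step among them can be read in this assay: the limit of > 60000 nM in this assay, at which 3 of the 4 values shown sit.

As far as these compounds go, whether methyl, bromo and chloro on this aromatic carbon differ at all in this assay remains open.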